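The source may hold more compounds than are shown below. What is called first, only, known or untested is meant among the compounds shown, and "the series" means these compounds.

Compound 1 `CCCC(=O)OCSc1ccccc1C(=O)NCCCNC(C)=O` is the reference point of this small series. In an ADME assay on CEM-SS cells (Homo sapiens) for cytotoxicity, read by XTT assay, with a stated time of 6 days (on this read-out higher numbers stand for lower toxicity in this test and lower numbers for higher toxicity in this test), compound 1 gives 21.1 uM, the lowest of the three numbers measured. Compound 2 `CCCC(=O)OCSc1ccccc1C(=O)N(C)CC(=O)NC` gives 62.5 uM in this assay, and compound 3 `CCCC(=O)OCSc1ccccc1C(=O)N(C)CC(=O)N(C)C` gives 57.3 uM. The steps of a 3.0-fold higher number from compound 1 to compound 2 (0.47 log units; beyond the scatter) and a 2.7-fold higher number from compound 1 to compound 3 (0.43 log units; beyond the scatter) both replace the (3-acetamidopropyl)amino group of compound 1 with a shorter chain that carries a second carbonyl, and both raise the number modestly. The step of a 1.1-fold lower number from compound 2 to compound 3 (0.04 log units; within the scatter) shows that a methyl in place of hydrogen on an amide-type nitrogen changes little.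

Compound 4 `CCCC(=O)OCSc1ccccc1C(=O)NCC(=O)NCC(N)=O` is the next compound to be measured. Its change from compound 1 is (carbamoylmethyl)carbamoyl in place of 2-acetamidoethyl on a saturated chain carbon bound to an amide-type nitrogen. Within the data shown here, the two steps from compound 1 to compounds 2 and 3 are the only measured steps that bear on it; both touch the same part of compound 1 and both moved the number upward by a modest amount. A modest upward step of a 2.1-fold higher number from compound 1 to compound 4 (0.33 log units; beyond the scatter) is therefore expected in this assay for compound 4, which is estimated at 45 uM, with a range from 20 uM to 100 uM.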

Compound 4, half-maximal toxic concentration: > 100 uM
Compound 4: no number, only a limit; the forecaster's own chance of this, stated with the estimate: 10%; middle value at least 2.2-fold (0.34 log units) away from the limit.
By their numbers in this assay, from the lowest: compound 1; then compounds 3 and 2 (each within the scatter of the next). At a limit, above all of these: compound 4.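

In this assay compound 4 gives > 100 uM, which is a limit of the assay and not a number. The step reads an at least 4.7-fold higher number from compound 1 to compound 4 (0.67 log units; beyond the scatter), so this position accepts (carbamoylmethyl)carbamoyl in place of 2-acetamidoethyl with a rise in the number that can only be bounded from one side. Compounds 2 and 3 both carry a methyl on the nitrogen attached to the carbonyl, whereas compound 4 keeps the amide hydrogen of compound 1, which shows that a change on the chain alone is enough to raise the number beyond the scatter.

Going by these compounds, the true size of this step stays open as long as only a limit stands for compound 4. Also open, on these data alone, is how this assay would read with a carboxylic acid, an amine or a longer chain in place of the (carbamoylmethyl)carbamoyl group.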